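Tert-butyl in Place of Methyl on a Lactam Analog

The compounds below may be only part of what the source reports. "The series", "measured", "known", "first", "only" and "open" are said of these compounds alone.

Measured so far:
Compound 1 `O=C1O/C(=C\Cn2cc(-c3ccccc3)nn2)C(OCc2ccccc2)=C1OCc1ccccc1` gives > 100000 nM in a functional assay on MCF7 cells (Homo sapiens) for antiproliferative activity, read by MTT assay, with a stated time of 24 h (a higher number here means a weaker inhibitor, a lower number a stronger inhibitor), a limit of the assay rather than a number.
Compound 2 `Cc1ccc(-c2cn(CCC3(O)NC(=O)C(OCc4ccccc4)=C3OCc3ccccc3)nn2)cc1` gives 24000 nM in this assay.
Compound 3 `CC(C)(C)c1ccc(-c2cn(C/C=C3\OC(=O)C(OCc4ccccc4)=C3OCc3ccccc3)nn2)cc1` gives > 100000 nM in this assay, again a limit rather than a number.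

Within the data shown here, compound 2 therefore stands as the only real number among the three results; the other two sit at the limit of > 100000 nM in this assay, at which 2 of the 3 values shown sit. Compound 4 `CC(C)(C)c1ccc(-c2cn(CCC3(O)NC(=O)C(OCc4ccccc4)=C3OCc3ccccc3)nn2)cc1` differs from compound 2 by tert-butyl in place of methyl on an aromatic carbon. Among the measured compounds shown here, the one measured step of a related kind, a step that the two limits leave unreadable from compound 1 to compound 3, cannot be read, so no step beyond the usual scatter is expected in this assay. Compound 4 is estimated at 30000 nM, between 8000 nM and 100000 nM, which means an expected step of a 1.3-fold higher number from compound 2 to compound 4 (0.10 log units; within the scatter).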

Compound 4, half-maximal inhibitory concentration: 25100 nM
Compound 4: middle estimate off by 1.2-fold (0.08 log units), on the high side; low and high end bracket the measured number.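

In this assay, tert-butyl in place of methyl on the aromatic ring gives a 1.0-fold higher number from compound 2 to compound 4 (0.02 log units; within the scatter), so on the core of compound 2 this position accepts 4 heavy atoms as readily as 1. The one earlier step of this kind cannot be read, as both its compounds sit at a limit: the limit of > 100000 nM in this assay, at which 2 of the 4 values shown sit.

Going by these compounds, whether an amine or a carboxylic acid at this position would leave the number where it stands remains open. So does whether a smaller group, such as a fluorine atom, would do the same.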